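Adding a hydroxy group to compound 3

This account rests on a few compounds, and the source may have more. Where it says the series, first, only, none or still open, it means among the compounds named here.

Measured so far in a functional assay on RS4-11 cells (Homo sapiens) for inhibition, read by CCK-8 assay, with a stated time of 48 h (a higher number here means a weaker inhibitor, a lower number a stronger inhibitor), are three compounds:
Compound 1 `O=S(=O)(NCCNC(=S)Nc1cccc(Cl)c1)c1ccc(-c2ccccc2OCc2cccc(O)c2)s1` gives 5800 nM
Compound 2 `O=[N+]([O-])c1ccc(NC(=S)NCCNS(=O)(=O)c2ccc(-c3ccccc3OCc3ccccc3)s2)cc1` gives 11300 nM
Compound 3 `O=[N+]([O-])c1cccc(NC(=S)NCCNS(=O)(=O)c2ccc(-c3ccccc3OCc3ccccc3)s2)c1` gives 11600 nM

Compound 3 stands at 11600 nM in this set, level with compound 2 and within the usual scatter of compound 1. The next compound, compound 4 `O=[N+]([O-])c1cccc(NC(=S)NCCNS(=O)(=O)c2ccc(-c3ccccc3OCc3cccc(O)c3)s2)c1`, carries one change from compound 3, hydroxy in place of hydrogen on an aromatic carbon, which turns benzyl into 3-hydroxybenzyl. For the measured compounds named here, the only measured single change, a 1.0-fold higher number from compound 2 to compound 3 (0.01 log units; within the scatter), swaps 4-nitrophenyl for 3-nitrophenyl elsewhere in the molecule, so it says nothing direct about a hydroxy group. A second place also separates compound 3 from compound 1, which carries the 3-hydroxybenzyl group and gives 5800 nM as a loose guide. No change beyond the scatter is therefore expected in this assay, with any shift leaning towards a lower number. The estimated step is a 1.5-fold lower number from compound 3 to compound 4 (0.16 log units; within the scatter) and is expected to stay small. For compound 4 the expected value is 8000 nM with 3500 nM to 16000 nM as the estimated range.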

Compound 4, half-maximal inhibitory concentration: 9800 nM
Beside the measured number, compound 4's estimate is 1.2-fold (0.09 log units) below it, within the range that was stated.
By their numbers in this assay, from the lowest: compounds 1, 4, 2 and 3 (each within the scatter of the next).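

In this assay, for the compounds shown here, the first direct reading of a hydroxy group at this position gives a 1.2-fold lower number from compound 3 to compound 4 (0.07 log units; within the scatter), so turning benzyl into 3-hydroxybenzyl produces no change that can be told from the scatter. With the 3-hydroxybenzyl group kept in place, nitro in place of chloro on an aromatic carbon gives a 1.7-fold higher number from compound 1 to compound 4 (0.23 log units; within the scatter), and this swap also stays within the scatter. No supporting evidence bears on either result.

On these data alone, whether a methoxy group, an amine or a carboxylic acid in place of the hydroxy would give a step beyond the scatter remains open. No step shown goes beyond the scatter, and which part of the molecule could produce one is also unresolved.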